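The source may hold more compounds than are shown below. What is called first, only, known or untested is meant among the compounds shown, and "the series" means these compounds.

Compound 1 `CS(=O)(=O)c1ccc(-c2nc(SCCCOC(=O)/C=C/c3ccc(O)c(O)c3)nn2-c2ccc(Br)cc2)cc1` and compound 2 `CS(=O)(=O)c1ccc(-c2nc(SCCCOC(=O)/C=C/c3ccc(O)c(O)c3)nn2-c2ccc(F)cc2)cc1` share one core; compound 3 `COc1cc(/C=C/C(=O)OCCSc2nc(-c3ccc(S(C)(=O)=O)cc3)n(-c3ccc(Br)cc3)n2)ccc1OC(C)=O` and compound 4 `COc1cc(/C=C/C(=O)OCCSc2nc(-c3ccc(S(C)(=O)=O)cc3)n(-c3ccc(F)cc3)n2)ccc1OC(C)=O` share another, and the difference between the two cores is not broken down here. In a functional assay on PC-3 cells (Homo sapiens) for antiproliferative activity, read by MTT assay, with a stated time of 72 h (a lower number here means a stronger inhibitor, a higher number a weaker inhibitor), compound 1 gives 12400 nM and compound 2 gives 10100 nM, while compound 3 gives 13100 nM. The change from compound 1 to compound 2 is fluoro in place of bromo on an aromatic carbon and it made a 1.2-fold lower number from compound 1 to compound 2 (0.09 log units; within the scatter). The same change is made from compound 3 to compound 4: fluoro in place of bromo on an aromatic carbon. The expectation for compound 4 rests on that earlier pair, because a 1.2-fold lower number from compound 1 to compound 2 (0.09 log units; within the scatter) gave no clear movement. The step from compound 3 to compound 4 is therefore estimated as a 1.1-fold lower number from compound 3 to compound 4 (0.06 log units; within the scatter). Compound 4 is expected to give about 11500 nM in this assay, with a likely range from 6000 nM to 22000 nM.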

Compound 4, half-maximal inhibitory concentration: 12800 nM
For compound 4 the middle estimate is 1.1-fold (0.05 log units) below the measured one; low and high end bracket the measured number.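

In this assay, going from 4-bromophenyl to 4-fluorophenyl on the second core gives a 1.0-fold lower number from compound 3 to compound 4 (0.01 log units; within the scatter), and the two cores read alike for this change: the same change on two cores in this assay, a 1.2-fold lower number (0.09 log units; within the scatter) from compound 1 to compound 2 and a 1.0-fold lower number (0.01 log units; within the scatter) from compound 3 to compound 4, 1.2-fold (0.08 log units) apart, within the scatter of two such steps

So in this series, the swap stays within the scatter on both cores, and a flat result on the first core was a fair guide to the second. This does not show that a change with a real effect would carry over in the same way, since neither step moves the number clearly, and two cores support no wider rule.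

Still open, from the compounds shown here alone, is whether other groups at this place, such as a nitrile or an amine, would move the number at all. If one did, it remains to be seen whether the shift would match on both cores.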